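The source may hold more compounds than are shown below. What is called first, only, known or untested is meant among the compounds shown, and "the series" means these compounds.

Of the compounds shown here, three of a shared core have been measured in an ADME assay on NIH3T3 cells (Mus musculus) for cytotoxicity, read by XTT assay, with a stated time of 24 h; on this read-out higher numbers stand for weaker inhibition and lower numbers for stronger inhibition. Compound 1 `Cn1nnnc1SCC(=O)N/N=C/c1cccc([N+](=O)[O-])c1` gives 2000000 nM, compound 2 `Cn1nnnc1SCC(=O)N/N=C/c1cccc(F)c1` gives 6320000 nM, and compound 3 `Cn1nnnc1SCC(=O)N/N=C/c1cccc(Br)c1` gives 316000 nM. Compound 3 stands lowest of the three: the step of a 6.3-fold lower number from compound 1 to compound 3 (0.80 log units; beyond the scatter) is modest, while the step of a 20-fold lower number from compound 2 to compound 3 (1.30 log units; beyond the scatter) is large, and the step of a 3.2-fold higher number from compound 1 to compound 2 (0.50 log units; beyond the scatter) is modest in the other direction.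

Compound 4 `Cn1nnnc1SCC(=O)N/N=C/c1cccc(O)c1` differs from compound 3 by one change, (hydroxy in place of bromo on an aromatic carbon), on an aromatic carbon of a six-membered aromatic ring of carbon only, meta to a large group. Going by the values given here, no measured step introduces a hydroxy group, so the bearing steps are those at the same aromatic carbon, a 20-fold lower number from compound 2 to compound 3 (1.30 log units; beyond the scatter) and a 6.3-fold lower number from compound 1 to compound 3 (0.80 log units; beyond the scatter), both of which end at the bromo compound with the lowest number. Since every substitution away from bromo among the measured compounds gave a higher number, a higher number is expected for compound 4 too, though the size is uncertain. The step expected in this assay is a 6.3-fold higher number from compound 3 to compound 4 (0.80 log units; beyond the scatter). Compound 4 is therefore estimated at 2000000 nM, with a range from 400000 nM to 10000000 nM.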

Compound 4, half-maximal inhibitory concentration: 3160000 nM
Compound 4: the middle estimate sits 1.6-fold (0.20 log units) below what was measured; the range from low to high includes it.
By their numbers in this assay, from the lowest: compound 3; then compounds 1, 4 and 2 (each within the scatter of the next, the first and the last beyond it).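

In this assay, the hydroxy compound does not stand with the bromo compound: the change shows a 10-fold higher number from compound 3 to compound 4 (1.00 log units; beyond the scatter), a modest step that leaves bromo set apart from all three other groups at this aromatic carbon. Against the remaining two groups, the hydroxy compound cannot be placed in any order, since the comparison with fluoro gives a 2.0-fold lower number from compound 2 to compound 4 (0.30 log units; within the scatter) and the comparison with nitro gives a 1.6-fold higher number from compound 1 to compound 4 (0.20 log units; within the scatter), even though compound 1 and compound 2 are separated beyond the scatter by a 3.2-fold higher number from compound 1 to compound 2 (0.50 log units; beyond the scatter) here. The earlier compounds shown here showed only that bromo, fluoro and nitro differ at this position, and the new result adds that a group counted with a hydrogen-bond donor and a hydrogen-bond acceptor, replacing a bromo group counted with neither, gives a number in the range of those of fluoro and nitro.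

From the compounds shown here alone, whether chloro, iodo, methoxy or an amine at this aromatic carbon would stand with bromo or with the other three remains open, as does whether the bromo result would hold at another carbon of the ring. Nothing measured among these compounds accounts for the way bromo stands apart from the other groups.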